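This account rests on a few compounds, and the source may have more. Where it says the series, first, only, none or still open, it means among the compounds named here.

Compound 1 (`O=C(O)CCNC(=O)c1ccc(CN(c2ccc(Cl)cc2)c2nc(-c3ccc(C(F)(F)F)cc3)cs2)cc1`) carries 4-chlorophenyl on a nitrogen on an aromatic ring, and compound 1 gives 2700 nM as a measured value in a functional assay on cells (Hepatocyte, Homo sapiens) for inhibition, with a stated time of 10 min (a higher number here means a weaker inhibitor, a lower number a stronger inhibitor), under these conditions. Compound 2 (`O=C(O)CCNC(=O)c1ccc(CN(c2ccc3c(c2)CCC3)c2nc(-c3ccc(C(F)(F)F)cc3)cs2)cc1`) has 2,3-dihydro-1H-inden-5-yl in that place. From the compounds shown here alone, for compound 2 the result in this assay is only a limit, < 20000 nM and not a number, so its place on the scale stays open. Within the data shown here, the one measured step is a step that the limit leaves unreadable from compound 1 to compound 2 and no size can be taken from it.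

Compound 3 (`O=C(O)CCNC(=O)c1ccc(CN(c2ccc(OC(F)(F)F)cc2)c2nc(-c3ccc(C(F)(F)F)cc3)cs2)cc1`) has 4-(trifluoromethoxy)phenyl in place of the 2,3-dihydro-1H-inden-5-yl of compound 2 (4-(trifluoromethoxy)phenyl in place of 2,3-dihydro-1H-inden-5-yl on a nitrogen on an aromatic ring). With no readable step to rely on, no direction can be stated with confidence against compound 2. Among the measured compounds shown here, the best guide is compound 1 at 2700 nM as the only compound with a number, since its 4-chlorophenyl is the closest group at hand to the incoming one. A result near that of compound 1 is therefore expected. The expected step is a step that the limit leaves unreadable from compound 2 to compound 3 as an estimate only. In this assay compound 3 is estimated at 2500 nM with an expected range from 800 nM to 8000 nM for a single measurement.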

Compound 3, half-maximal inhibitory concentration: 3600 nM
Compound 3: the middle estimate sits 1.4-fold (0.16 log units) below what was measured; the range from low to high includes it.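

In this assay, among these compounds, trifluoromethoxy in place of chloro on an aromatic carbon gives a 1.3-fold higher number from compound 1 to compound 3 (0.12 log units; within the scatter), the first step at this position whose size can be read. On this evidence, the assay does not tell 4-(trifluoromethoxy)phenyl from 4-chlorophenyl on a nitrogen on an aromatic ring, although the incoming group has an oxygen and three fluorine atoms where the other has a single chlorine. The two steps that involve compound 2 cannot be read, as the result for compound 2 is only a limit: the limit of < 20000 nM in this assay, at which 1 of the 3 values shown sits.

From the compounds shown here alone, it therefore stays open whether 2,3-dihydro-1H-inden-5-yl at this place gives a number different from those of compound 1 and compound 3. The two compounds with numbers also say nothing about how a plain phenyl, a 4-methoxyphenyl, a 4-aminophenyl or a pyridine ring at this place would compare, so a single pair within the scatter cannot show whether this position generally tolerates change or whether these two groups merely happen to match.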